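A few compounds are considered here, and "the series" means these few. Any claim that something is new, unique, unknown or untested is made for them only; others in the source may bear on it.

Compound 3, `Cc1ccc(-c2csc(N/N=C/c3ccc(Cl)cc3Cl)n2)cc1`, belongs to a small set that also holds compound 1, `COC(=O)c1cc(-c2csc(N/N=C/c3cccs3)n2)ccc1OCc1ccccc1`, and compound 2, `Fc1ccc(-c2csc(N/N=C/c3ccc(Cl)cc3Cl)n2)cc1`. All three were run in a functional assay, read by spectrophotometry, with a stated time of 15 min, tested at 80 ug/mL; a lower number here means a weaker effect, a higher number a stronger effect of the compound at the concentration tested. In this assay compound 1 gives 87.6%, compound 2 gives 94%, and compound 3 gives 84.2%, the lowest of the three numbers, though its gap to each of the other two is within the scatter. Going by the values given here, the one single-point step among the measured compounds, a number 9.8 percentage points lower from compound 2 to compound 3 (within the scatter), exchanges groups on the same aromatic carbon that is now in question and stays within the scatter. Compound 4, `COc1ccc(-c2csc(N/N=C/c3ccc(Cl)cc3Cl)n2)cc1`, differs from compound 3 by methoxy in place of methyl on an aromatic carbon. Among the compounds with values here, no measured compound carries a methoxy group, so the expectation rests only on the observation that swapping a small group at this place moved the read-out little. Compound 4 is therefore expected to give 86% in this assay, between 74% and 95%, which means an expected step of a number 1.8 percentage points higher from compound 3 to compound 4 (within the scatter), not beyond the scatter.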

Compound 4, a percentage reported as inhibition, at one concentration (the size of the read-out at that concentration, not a potency): 84.2%
The estimate for compound 4 lay 1.8 percentage points above the measured number; low and high end bracket the measured number.
By their numbers in this assay, from the lowest: compounds 3, 4, 1 and 2 (each within the scatter of the next).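

In this assay, the change from 4-methylphenyl to 4-methoxyphenyl gives no change at the digits printed from compound 3 to compound 4 (within the scatter) even though it adds an oxygen and a hydrogen-bond acceptor on this aromatic carbon, para to a large group. The step of a number 9.8 percentage points lower from compound 2 to compound 4 (within the scatter) stays within the scatter as well, so all three groups seen at this carbon, fluoro, methyl and methoxy, now give numbers within the scatter of one another. Nothing measured here offers an explanation for this flat result.

Going by these compounds, it remains open whether an amine, a carboxylic acid or a longer chain at this carbon would also stay within the scatter. On these data alone, it is also open whether methoxy would behave the same way with a different group on the far side of the shared core, as in compound 1.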